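Swapping iodo for fluoro on a cytotoxicity series

The source may report more compounds than this note shows. Statements on the series, on what has been measured and on what is new or still open speak of the compounds shown alone.

Of the compounds shown here, three sharing one core have been tested in an ADME assay on J774 cells (Mus musculus, strain BALB/c) for cytotoxicity, read by resazurin assay, with a stated time of 72 h; a higher number here means that more compound is tolerated, a lower number that less compound is tolerated. Compound 1 `COc1ccc(C(=O)N/N=C(C)/C=N/Nc2ccc([N+](=O)[O-])cc2)cc1` gives only a limit of the assay, > 100000 nM, rather than a number. Compound 2 `CC(/C=N/Nc1ccc([N+](=O)[O-])cc1)=N\NC(=O)c1ccccc1N` gives 29800 nM in this assay. Compound 3 `CC(/C=N/Nc1ccc([N+](=O)[O-])cc1)=N\NC(=O)c1ccccc1I` gives 40000 nM in this assay; of the two plain numbers it stands nearest to compound 2, and a 1.3-fold higher number from compound 2 to compound 3 (0.13 log units; within the scatter) places the pair within the scatter. The remaining measured steps are an at least 3.3-fold lower number from compound 1 to compound 2 (0.52 log units; beyond the scatter) and an at least 2.5-fold lower number from compound 1 to compound 3 (0.39 log units; beyond the scatter), both replacing the 4-methoxyphenyl group.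

Compound 4 `CC(/C=N/Nc1ccc([N+](=O)[O-])cc1)=N\NC(=O)c1ccccc1F` is not yet measured. It differs from compound 3 by fluoro in place of iodo on an aromatic carbon. The step that bears most directly on this change is a 1.3-fold higher number from compound 2 to compound 3 (0.13 log units; within the scatter), where a different group at the same aromatic carbon ortho to a large group left the number within the scatter. A similarly small movement is therefore expected for compound 4, amounting to no change at the digits printed from compound 3 to compound 4 (within the scatter). Compound 4 is estimated at 40000 nM, with a range from 20000 nM to 90000 nM.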

Compound 4, half-maximal cytotoxic concentration: > 100000 nM
Compound 4: only a limit was reported (the forecaster's own chance of this, stated with the estimate: 20%); middle value at least 2.5-fold (0.39 log units) from the limit.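

In this assay, the earlier swap at this aromatic carbon, ortho to a large group, left the number within the scatter, so the position could have seemed indifferent to the group it carries. Fluoro shows otherwise, with an at least 2.5-fold higher number from compound 3 to compound 4 (0.39 log units; beyond the scatter) and an at least 3.3-fold higher number from compound 2 to compound 4 (0.52 log units; beyond the scatter), so a single atom changed here can move the result beyond the scatter. Compound 4 reads only as a limit of the assay, so these steps are minimum sizes, and the step between compound 1 and compound 4 cannot be read: the limit of > 100000 nM in this assay, at which 2 of the 4 values shown sit.

With only amino, iodo and fluoro at this carbon, the compounds shown cannot tell whether chloro or bromo would sit nearer to iodo or to fluoro. On these data alone, how far compound 4 lies past its limit also stays open, as does whether a hydroxyl or methyl group here would behave like fluoro.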